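Compound 4: from benzylamine to arylamine

This account rests on a few compounds, and the source may have more. Where it says the series, first, only, none or still open, it means among the compounds named here.

Among the measured compounds shown here, in a functional assay on MDA-MB-231 cells (Homo sapiens) for inhibition, read by CCK-8 assay, with a stated time of 48 h (on this read-out lower numbers stand for stronger inhibition of growth and higher numbers for weaker inhibition of growth), compound 3 `COc1cccc(CNc2nc(Nc3ccc(N4CCN(C)CC4)cn3)ncc2Cl)c1` gives 20300 nM as the only true number. Compound 1 `CCN1CCN(c2ccc(Nc3ncc(Cl)c(Nc4ccccc4C)n3)nc2)CC1` stands at > 100000 nM and that is a limit. Compound 2 `CN1CCN(c2ccc(Nc3ncc(Cl)c(NCc4ccc(F)cc4)n3)nc2)CC1` stands at > 100000 nM and that too is a limit.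

Compound 4 `CC(C)c1ccc(Nc2nc(Nc3ccc(N4CCN(C)CC4)cn3)ncc2Cl)cc1` differs from compound 3 thus: 4-isopropylphenyl in place of 3-methoxybenzyl on a nitrogen on an aromatic ring with 4-isopropylphenyl in place of 3-methoxybenzyl on a nitrogen on an aromatic ring. For the measured compounds named here, one measured step bears on this, an at least 4.9-fold lower number from compound 2 to compound 3 (0.69 log units; beyond the scatter) and it is of at least modest size, but it swapped groups on a saturated chain carbon, so its direction does not carry over. No step beyond the scatter is therefore expected in this assay although the limit of > 100000 nM in this assay, at which 2 of the 3 values shown sit, stays within reach. Compound 4 is estimated at 25000 nM with an expected range of 6000 nM to 90000 nM for the measurement. The expected change is a 1.2-fold higher number from compound 3 to compound 4 (0.09 log units; within the scatter) and no more.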

Compound 4, concentration for 50% growth inhibition: 7020 nM
The estimate for compound 4 lay 3.6-fold (0.55 log units) above the measured number, and the stated range covers the measured number.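

In this assay, the nitrogen on an aromatic ring accepts 4-isopropylphenyl bound directly in place of 3-methoxybenzyl, giving a 2.9-fold lower number from compound 3 to compound 4 (0.46 log units; beyond the scatter). The same group in place of 4-fluorobenzyl gives an at least 14-fold lower number from compound 2 to compound 4 (1.15 log units; beyond the scatter). That second step is only a bound, since compound 2 is a limit: the limit of > 100000 nM in this assay, at which 2 of the 4 values shown sit.

The compounds shown leave open whether the shift follows the loss of the chain carbon or the arrival of the isopropyl group; the two change together. A 4-isopropylbenzyl group or an unsubstituted phenyl on this nitrogen would separate them.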